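Shortening the Acid Side Chain on a Shared Core

The compounds below may be only part of what the source reports. "The series", "measured", "known", "first", "only" and "open" are said of these compounds alone.

Compound 1 `CCC(C(=O)O)c1nn(Cc2cn3cc(OCC4CC4)c(Cl)cc3n2)c2ccccc2c1=O` is one of two measured compounds. In a functional assay on CHO cells for antagonist activity at sphingosine 1-phosphate receptor 2 (Homo sapiens), read by calcium flux (a higher number here means a weaker inhibitor, a lower number a stronger inhibitor), compound 1 gives 5.6 nM, the lower of the two numbers, while compound 2 `CCOc1cc2[nH]c(Cc3nn(CC(=O)N4CCOCC4)c(=O)c4ccccc34)nc2cc1Cl` gives 10 nM, a gap that falls within the usual scatter. Compound 3 `C[C@H](C(=O)O)c1nn(Cc2cn3cc(OCC4CC4)c(Cl)cc3n2)c2ccccc2c1=O` differs from compound 1 in one place: 1-carboxyethyl in place of 1-carboxypropyl on an aromatic carbon. No step of this kind has been measured among these compounds, so only a small step, if any, is expected. Compound 3 is expected to give 8 nM (between 2 nM and 30 nM), which means an estimated step of a 1.4-fold higher number from compound 1 to compound 3 (0.15 log units; within the scatter).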

Compound 3, half-maximal inhibitory concentration in the sphingosine 1-phosphate receptor 2 assay: 3.2 nM
Compound 3: the middle estimate sits 2.5-fold (0.40 log units) above what was measured; the measured number falls inside the stated range.
By their numbers in the sphingosine 1-phosphate receptor 2 assay, from the lowest: compounds 3, 1 and 2 (each within the scatter of the next, the first and the last beyond it).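

For the compounds shown here, in the sphingosine 1-phosphate receptor 2 assay the change to 1-carboxyethyl in place of 1-carboxypropyl gives a 1.8-fold lower number from compound 1 to compound 3 (0.24 log units; within the scatter), so this position on the shared core takes the shorter chain with no step that stands out from the scatter. In a physicochemical assay for solubility, measured as thermodynamic solubility, at pH 7.4 (a lower number here means a less soluble compound, a higher number a more soluble compound), compound 1 gives 359 ug/mL and compound 3 gives 892 ug/mL, which makes a 2.5-fold higher number from compound 1 to compound 3 (0.40 log units; beyond the scatter). This pair therefore separates in that read-out but not in inhibition.

The compounds shown leave open how a carboxymethyl group or a primary amide would behave at this position. They also leave open how the opposite configuration of the defined stereocentre in compound 3 would compare.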